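Chloro for fluoro on the benzyl of an adenosine antagonist

The source may hold more compounds than are shown below. What is called first, only, known or untested is meant among the compounds shown, and "the series" means these compounds.

Compound 1 `CNc1nc(-c2ccccc2)nc2c1nnn2Cc1ccccc1Cl`: 191000000 nM
Compound 2 `Fc1ccccc1Cn1nnc2c(NC3CCCCC3)nc(-c3ccccc3)nc21`: 1150000 nM

In an assay on isolated protein for binding affinity to adenosine receptor A1 (Bos taurus) (a higher number here means a weaker inhibitor, a lower number a stronger inhibitor), compound 2 gives the lowest of the two numbers measured; compound 1 sits far higher, beyond the scatter. Compound 3 `Clc1ccccc1Cn1nnc2c(NC3CCCCC3)nc(-c3ccccc3)nc21` has not yet been measured. It differs from compound 2 by chloro in place of fluoro on an aromatic carbon. Within the data shown here, no measured pair isolates this swap, so the expected step from compound 2 to compound 3 is a 1.2-fold lower number from compound 2 to compound 3 (0.06 log units; within the scatter), in neither direction beyond the scatter. Compound 3 is therefore estimated at 1000000 nM, with a range from 300000 nM to 4000000 nM.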

Compound 3, inhibition constant: 34000000 nM
Estimate against measurement, compound 3: 34-fold (1.53 log units) below, and the stated range ends below it.
By their numbers in this assay, from the lowest: compound 2; then compound 3; then compound 1.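

In this assay the change from 2-fluorobenzyl to 2-chlorobenzyl gives a 30-fold higher number from compound 2 to compound 3 (1.47 log units; beyond the scatter) and so shows that this place, ortho to a large group, distinguishes the two halogens sharply. With chloro held fixed, cyclohexyl in place of methyl on the nitrogen gives a 5.6-fold lower number from compound 1 to compound 3 (0.75 log units; beyond the scatter) and so shows that this second site also matters, though by a smaller step than the halogen swap.

As far as these compounds go, how a bromo, a methoxy or a plain hydrogen would read at this place remains open. Nothing given here explains either step.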